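Shortening the Chain on the Shared Core

The source may hold more compounds than are shown below. What is called first, only, known or untested is meant among the compounds shown, and "the series" means these compounds.

Compounds measured so far:
- compound 1, `CCCCCCCCc1cn([C@H]2C[C@H](O)[C@@H](CO)O2)c(=O)[nH]c1=O`: 52 ug/mL
- compound 2, `CCc1cn([C@H]2C[C@@H]3OP(=O)(O)OC[C@H]3O2)c(=O)[nH]c1=O`: 60 ug/mL
- compound 3, `CC(C)c1cn([C@H]2C[C@@H]3OP(=O)(O)OC[C@H]3O2)c(=O)[nH]c1=O`: > 500 ug/mL

In a functional assay on Raji cells (Homo sapiens) (a lower number here means a stronger inhibitor, a higher number a weaker inhibitor), compound 1 gives the lowest of the two numbers shown, and compound 2 sits within the scatter of it. For compound 3 this assay reports only a limit, (the limit of > 500 ug/mL in this assay, at which 1 of the 3 values shown sits). Among the measured compounds shown here, the one step measured, an at least 8.3-fold higher number from compound 2 to compound 3 (0.92 log units; beyond the scatter), concerns a branching change, not chain length. Compound 4, `CCCc1cn([C@H]2C[C@H](O)[C@@H](CO)O2)c(=O)[nH]c1=O`, differs from compound 1 by hydrogen in place of pentyl on a saturated chain carbon, three bonds along the chain from an aromatic carbon. For the measured compounds named here, no measured step bears on a shortening of this kind, so the expectation rests on compound 1 alone with wide uncertainty. Compound 4 is estimated at 80 ug/mL (range 25 ug/mL to 300 ug/mL), an expected step of a 1.5-fold higher number from compound 1 to compound 4 (0.19 log units; within the scatter).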

Compound 4, concentration for 50% inhibition: > 500 ug/mL
Compound 4: only a limit was reported; the forecaster's own chance of this, stated with the estimate: 20%; at least 6.2-fold (0.79 log units) between middle value and limit.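

Cutting the chain from octyl to propyl gives an at least 9.6-fold higher number from compound 1 to compound 4 (0.98 log units; beyond the scatter) in this assay, so on this core the length of the chain at this position counts, which no earlier step could show. The reading for compound 4 is a limit, not a number, so the full size of the step stays unknown: the limit of > 500 ug/mL in this assay, at which 2 of the 4 values shown sit.

Still open, on these data alone, is how the number changes for chains between propyl and octyl. Also open, as far as these compounds go, is whether a chain longer than octyl, or an amine at the end of the chain, would give a lower number.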